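A few compounds are considered here, and "the series" means these few. Any claim that something is new, unique, unknown or untested is made for them only; others in the source may bear on it.

Compound 1 `CC(=O)NCC(=O)N(C)c1ccc(Cl)cc1C(=O)c1ccccc1Cl`: 58 mg/kg
Compound 2 `CC(NC(=O)CN)C(=O)N(C)c1ccc(Cl)cc1C(=O)c1ccccc1Cl`: 8.5 mg/kg
Compound 3 `CCCCCCC(=O)NCC(=O)N(C)c1ccc(Cl)cc1C(=O)c1ccccc1Cl`: 70 mg/kg
Compound 4 `CCCCC(=O)NCC(=O)N(C)c1ccc(Cl)cc1C(=O)c1ccccc1Cl`: not yet measured

These values come from a functional assay on the whole organism with Mus musculus as the target, in the rotarod test; a lower number here means that less compound is needed, a higher number that more compound is needed for the effect. Compound 3 is level with one measured neighbour and clearly apart from the other: the data show a 1.2-fold higher number from compound 1 to compound 3 (0.08 log units; within the scatter), and also an 8.2-fold higher number from compound 2 to compound 3 (0.92 log units; beyond the scatter).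

Compound 4 trims the chain of compound 3: hydrogen in place of ethyl on a saturated chain carbon, four bonds along the chain from a carbonyl carbon. In words, this is hydrogen in place of ethyl on a saturated chain carbon, four bonds along the chain from a carbonyl carbon. The chain of compound 4 is shorter than that of compound 3 and longer than that of compound 1.

Within the data shown here, the most relevant step is the one that changes this same chain, a 1.2-fold higher number from compound 1 to compound 3 (0.08 log units; within the scatter). Lengthening the chain by more than this change did not move the number beyond the scatter. By contrast, a 6.8-fold lower number from compound 1 to compound 2 (0.83 log units; beyond the scatter) alters a different part of the molecule and says little here.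

The expected step is a 1.1-fold lower number from compound 3 to compound 4 (0.05 log units; within the scatter), which would stay within the scatter. The estimated value for compound 4 is 63 mg/kg, with an expected range from 32 mg/kg to 120 mg/kg.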

Compound 4, dose for half-maximal effect: 90 mg/kg
Compound 4: middle estimate off by 1.4-fold (0.15 log units), on the low side; the range from low to high includes it.
By their numbers in this assay, from the lowest: compound 2; then compounds 1, 3 and 4 (each within the scatter of the next).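

With compound 4, three chain lengths can now be compared at this position. Replacing ethyl with hydrogen gives a 1.3-fold higher number from compound 3 to compound 4 (0.11 log units; within the scatter) in this assay and, starting from the shortest chain, placing propyl on the carbon bound to the carbonyl gives a 1.6-fold higher number from compound 1 to compound 4 (0.19 log units; within the scatter) in the same test, so the intermediate chain also stands level with the other two. The only clear separation is an 11-fold higher number from compound 2 to compound 4 (1.02 log units; beyond the scatter) and this step replaces the whole side chain, so it cannot be traced to chain length alone.

No measurement here explains why these chains sit so close together. From the compounds shown here alone, it remains open whether this level picture would hold for a longer chain such as decyl, or for a carboxylic acid at the end of the chain.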